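From a Methoxy Carbonyl to a Formylamino Side Chain

A few compounds are considered here, and "the series" means these few. Any claim that something is new, unique, unknown or untested is made for them only; others in the source may bear on it.

In a functional assay on HCT-15 cells (Homo sapiens) (on this read-out lower numbers stand for an effect already at smaller amounts and higher numbers for an effect only at larger amounts of compound), compound 1 `CCCCNC(=O)c1c(OC)cc(C2OC(c3ccc(N)c(C)c3)=NN2C(C)=O)cc1OC` gives 178 uM and compound 2 `COC(=O)c1c(OC)cc(C2OC(c3ccc(N)c(C)c3)=NN2C(C)=O)cc1OC` gives 0.28 uM, while compound 3 `COC(=O)N1N=C(c2ccc(N(C)C)cc2)OC1c1cc(OC)c(OC)c(OC)c1` gives 40 uM, the second highest of the three numbers. Compound 4 `COc1cc(C2OC(c3ccc(N(C)C)cc3)=NN2C(=O)CNC=O)cc(OC)c1OC` differs from compound 3 by (formylamino)methyl in place of methoxy on a carbonyl carbon, with (formylamino)methyl in place of methoxy on a carbonyl carbon. Within the data shown here, one measured step bears on this change, a 640-fold lower number from compound 1 to compound 2 (2.80 log units; beyond the scatter), which also concerns methoxy on a carbonyl carbon, but a different carbonyl on a different core. That large step hints only loosely that losing methoxy could raise the number in this assay. The expected outcome is a 1.5-fold higher number from compound 3 to compound 4 (0.18 log units; within the scatter), a small estimated change with weak support. For compound 4 the estimated value is 60 uM, with an expected range from 8 uM to 300 uM.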

Compound 4, concentration for half-maximal effect: 0.035 uM
Beside the measured number, compound 4's estimate is 1700-fold (3.23 log units) above it, and the stated range ends above it.
By their numbers in this assay, from the lowest: compound 4; then compound 2; then compound 3; then compound 1.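

On the carbonyl carbon whose other neighbour is an amide-type nitrogen in a ring, (formylamino)methyl in place of methoxy gives a 1100-fold lower number from compound 3 to compound 4 (3.06 log units; beyond the scatter) in this assay. Among these compounds, the earlier compounds showed a large step only at a different carbonyl on a different core, so this is the first sign that the group at this position can move the number so far. Nothing measured here accounts for the size of this step.

As far as these compounds go, it remains open whether aminomethyl, or a longer chain such as (formylamino)ethyl, on this carbonyl carbon would keep the number this low.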